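A few compounds are considered here, and "the series" means these few. Any claim that something is new, unique, unknown or untested is made for them only; others in the source may bear on it.

In a functional assay on HCT-116 cells (Homo sapiens) for antiproliferative activity, read by CellTiter-Glo, with a stated time of 72 h (a higher number here means a weaker inhibitor, a lower number a stronger inhibitor), compound 1 `O=C(NO)c1ccc(/C=C/c2ccnc(-c3cccc(CO)c3)c2)cc1` gives 1700 nM. That sits level, within the usual scatter, with compound 3 `Cc1ccc(-c2cc(/C=C/c3ccc(C(=O)NO)cc3)c(F)cn2)c(F)c1`, which gives 1670 nM. Compound 2 `O=C(NO)c1ccc(/C=C/c2cc(-c3ccc(C(F)(F)F)cc3)ncc2F)cc1` reads > 10000 nM, which is a limit of the assay and not a number. Compound 4 `O=C(NO)c1ccc(/C=C/c2ccncc2)cc1` takes the core of compound 1 and carries hydrogen in place of 3-(hydroxymethyl)phenyl on an aromatic carbon. For the measured compounds named here, no measured pair isolates a change of this kind, so the expectation is loose: a small weakening in this assay, meaning a higher number, and perhaps nothing beyond the scatter. The step expected is a 1.8-fold higher number from compound 1 to compound 4 (0.25 log units; within the scatter). For compound 4 the estimated value is 3000 nM, with an expected range of 800 nM to 10000 nM.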

Compound 4, half-maximal inhibitory concentration: 3910 nM
Compound 4: the middle estimate sits 1.3-fold (0.12 log units) below what was measured; measured number inside the range.
By their numbers in this assay, from the lowest: compounds 3 and 1 (each within the scatter of the next); then compound 4. At a limit, above all of these: compound 2.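

In this assay the swap of 3-(hydroxymethyl)phenyl for hydrogen on the aromatic carbon next to the ring nitrogen gives a 2.3-fold higher number from compound 1 to compound 4 (0.36 log units; beyond the scatter) as a modest weakening. The large group therefore adds something at this position, yet compound 4 keeps a measurable value with only hydrogen there, so activity in these cells does not depend entirely on that group. Nothing given here explains why the step has this size.

From the compounds shown here alone, whether the gain comes from the benzene ring or from its hydroxymethyl stays open. A plain phenyl would separate the two, and a methyl or an amine at this position would show whether a much smaller group can match compound 1.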